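The source may hold more compounds than are shown below. What is called first, only, known or untested is meant among the compounds shown, and "the series" means these compounds.

Measured compounds:
Compound 1 `C=CCNC(=S)N/N=C/C=C/c1ccc([N+](=O)[O-])o1`: in an ADME assay on J774 cells (Mus musculus) for cytotoxicity, read by MTT assay, with a stated time of 48 h (on this read-out lower numbers stand for stronger inhibition and higher numbers for weaker inhibition), compound 1 gives 200 uM.
Compound 2 `C=CCNC(=S)N/N=C/C=C/c1ccc([N+](=O)[O-])s1`: in this assay compound 2 gives only a limit, < 100 uM.

Compound 2 therefore stands at the limit of < 100 uM in this assay, at which 1 of the 2 values shown sits, and no exact number is known for it. Compound 3 `C=CCNC(=S)N/N=C/C=C/c1cccs1` differs from compound 2 by hydrogen in place of nitro on an aromatic carbon. Going by the values given here, no step between measured compounds is available to size this change. Without the nitro group, weaker inhibition, a higher number, is expected for compound 3, and the estimated step is an at least 1.5-fold higher number from compound 2 to compound 3 (0.17 log units; that floor lies within the scatter). Compound 3 is thus expected to give about 150 uM in this assay, within 50 uM to 400 uM.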

Compound 3, concentration for 50% inhibition: > 400 uM
Compound 3 ended at the assay's limit (the forecaster's own chance of this, stated with the estimate: 30%); at least 2.6-fold (0.42 log units) between middle value and limit.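

Going by these compounds alone, on the aromatic carbon next to the ring sulfur, hydrogen in place of nitro gives an at least 4.0-fold higher number from compound 2 to compound 3 (0.60 log units; beyond the scatter) in this assay, the first sized step for this change, and it lies beyond the scatter. On these data alone, each end of this step is a limit of the assay and not a number, so the step gives only a floor and its true size stays unknown.

As far as these compounds go, whether an amine or a carboxylic acid at this position would read closer to nitro or to hydrogen remains open. From the compounds shown here alone, it is also open whether the same change on the core of compound 1 would give a step of similar size.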